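Ring Size at the Amide of a Proline Nitrile Pair

This account rests on a few compounds, and the source may have more. Where it says the series, first, only, none or still open, it means among the compounds named here.

compound 1, `N#C[C@@H]1CCCN1C(=O)[C@@H]1C[C@H](C(=O)N2CCCCCCC2)CN1`, 63%
compound 2, `C[C@@H]1N[C@H](C(=O)N2CCC[C@H]2C#N)C[C@@H]1C(=O)N1CCC1`, 94%

Of the compounds shown here, two have been measured in an assay on the whole organism (plasma, strain Sprague-Dawley) for inhibition of Dipeptidyl peptidase 4 (Rattus norvegicus), with a stated time of 6 h, at a dose of 1 mg/kg by the oral route; on this read-out lower numbers stand for less inhibition and higher numbers for more inhibition at the one dose given (going by the name of the read-out). In this assay compound 1 gives 63%, and compound 2 gives 94%. Compound 2 thus stands highest of the two numbers, and its gap to compound 1 lies beyond the usual scatter. Going by the values given here, no step between compounds that differ in a single place has been measured, so the two values show only that the number of compound 2 is the higher of the pair.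

Compound 3, `C[C@@H]1N[C@H](C(=O)N2CCC[C@H]2C#N)C[C@@H]1C(=O)N1CCCC1`, differs from compound 2 in one place: pyrrolidin-1-yl in place of azetidin-1-yl on a carbonyl carbon. The measured pair gives no direct guide to this change. A step of a number 6 percentage points lower from compound 2 to compound 3 (within the scatter) is expected, small and within the scatter, since compound 2 already sits near the top of the read-out. Compound 3 is estimated at 88%, with a range from 70% to 98%.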

Compound 3, a percentage reported as inhibition, in the whole organism at one dose (the size of the read-out at that dose, not a potency): 94%
The estimate for compound 3 lay 6 percentage points below the measured number; measured number inside the range.
By their numbers in this assay, from the lowest: compound 1; then compounds 2 and 3 (each within the scatter of the next).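

Replacing azetidin-1-yl with pyrrolidin-1-yl on a carbonyl carbon gave no change at the digits printed from compound 2 to compound 3 (within the scatter) in this assay. Going by these compounds alone, this is the first step read at this position, and it shows that the four-membered and five-membered rings cannot be told apart on this read-out at the one dose and time given. Nothing measured on these compounds offers an explanation for this result.

On these data alone, it remains open whether other groups on the same carbonyl carbon, such as piperidin-1-yl, morpholin-4-yl or an open-chain dimethylamino group, would hold the read-out at this level. Also open, as far as these compounds go, is whether compound 2 and compound 3 would separate at a lower dose or a later time, as a single-dose percentage does not give their potency.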